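A hydroxy group in place of bromo on the anilide

The compounds below may be only part of what the source reports. "The series", "measured", "known", "first", "only" and "open" are said of these compounds alone.

Of the compounds shown here, three sharing one core have been measured in a functional assay on NCI-H460 cells (Homo sapiens) for inhibition, read by CCK-8 assay, with a stated time of 72 h, tested at 1 uM; on this read-out higher numbers stand for more inhibition of growth at the one concentration tested and lower numbers for less inhibition of growth. Compound 1 `CN(C)C(=O)c1cc2cnc(Nc3ccc(NC(=O)C4(C(=O)Nc5ccccc5)CC4)cc3)nc2n1C1CCCC1` carries an unsubstituted anilide and in this assay gives 42.4%. Compound 3 `CN(C)C(=O)c1cc2cnc(Nc3ccc(NC(=O)C4(C(=O)Nc5ccc(Br)cc5)CC4)cc3)nc2n1C1CCCC1` carries a bromo group on that ring and gives 31.5%, while compound 2 `CN(C)C(=O)c1cc2cnc(Nc3ccc(NC(=O)C4(C(=O)Nc5ccc(F)cc5)CC4)cc3F)nc2n1C1CCCC1`, which differs from it at several places, gives 11.9%. Compound 3 thus stands second highest of the three numbers, with compound 1 nearest above it and compound 2 furthest below it. For the measured compounds named here, the only single step measured so far runs a number 10.9 percentage points lower from compound 1 to compound 3 (beyond the scatter).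

Compound 4 `CN(C)C(=O)c1cc2cnc(Nc3ccc(NC(=O)C4(C(=O)Nc5ccc(O)cc5)CC4)cc3)nc2n1C1CCCC1` differs from compound 3 in one place: hydroxy in place of bromo on an aromatic carbon. Going by the values given here, no measured step shows a hydroxy group entering at this position, so the step from compound 1 to compound 3 bears on it only indirectly: removing the hydrogen for bromo cost a modest amount, and the hydroxy group is a third, untested option at the same carbon. The values of compound 1 and compound 3 bracket what seems most plausible for a third substituent there.

Compound 4 is therefore expected to land near the middle of that bracket, at 35% with a range from 20% to 50%. The expected step of a number 3.5 percentage points higher from compound 3 to compound 4 (within the scatter) is estimated to lie within the scatter, in either direction.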

Compound 4, percent growth inhibition at one concentration: 90.4%
Compound 4: the middle estimate sits 55.4 percentage points below what was measured, and the stated range ends below it.
By their numbers in this assay, from the lowest: compound 2; then compound 3; then compound 1; then compound 4.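

In this assay, for the compounds shown here, the aromatic carbon of the anilide ring, para to a large group, proves far more sensitive to its substituent than the earlier compounds showed: the only step known before, a number 10.9 percentage points lower from compound 1 to compound 3 (beyond the scatter), was modest, whereas exchanging bromo for hydroxy gives a number 58.9 percentage points higher from compound 3 to compound 4 (beyond the scatter). The rise is not simply a recovery of what bromo lost, as the step of a number 48 percentage points higher from compound 1 to compound 4 (beyond the scatter) carries the number well past that of the unsubstituted anilide, so the two groups at this one carbon move the read-out in opposite directions relative to hydrogen. Nothing available here explains why hydroxy and bromo part so widely at this carbon.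

The compounds shown leave open whether this rise is particular to the hydroxy group or would also appear with a methoxy group, an amine or a carboxylic acid at the same carbon. They also leave open whether a hydroxy group on another carbon of this ring would give a similar number, and whether its effect would persist with a fluoro group on the central ring.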